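The source may report more compounds than this note shows. Statements on the series, on what has been measured and on what is new or still open speak of the compounds shown alone.

Measured compounds:
- compound 1, `CCCCCCCCCCc1ccccc1C(SCCC(=O)O)SCCC(=O)O`: 1180 nM
- compound 2, `CCCCCCCCCCC#Cc1ccccc1C(SCCC(=O)O)SCCC(=O)O`: 2520 nM
- compound 3, `CCCCCCCCCCCOc1ccccc1C(SCCC(=O)O)SCCC(=O)O`: 287 nM

In an assay on membranes from lung (Cavia porcellus) for binding affinity to cysteinyl leukotriene receptor (Homo sapiens) (a lower number here means a stronger inhibitor, a higher number a weaker inhibitor), compound 3 gives the lowest number of the three. Compound 1, which carries a decyl chain directly on the ring rather than through an oxygen, gives 1180 nM in this assay, and compound 2, with a dodec-1-yn-1-yl chain, gives 2520 nM; both of these gaps from compound 3 lie beyond the usual scatter. Within the data shown here, no single-point comparison between the measured compounds is available, so no measured step can be quoted.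

Compound 4, `CCCCC/C=C/C/C=C/COc1ccccc1C(SCCC(=O)O)SCCC(=O)O`, differs from compound 3 by one change: deca-1,4-dien-1-yl in place of decyl on a saturated chain carbon bound to an oxygen on an aromatic ring. The chain keeps the same length and the same oxygen link to the ring; only two double bonds are introduced into it. Nothing measured here isolates the effect of such double bonds, so the expected step is cautious: a small weakening, not clearly beyond the scatter, given as a 1.7-fold higher number from compound 3 to compound 4 (0.24 log units; within the scatter). Compound 4 is therefore estimated at 500 nM in this assay, with a range from 150 nM to 1800 nM.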

Compound 4, inhibition constant: 1000 nM
Estimate against measurement, compound 4: 2.0-fold (0.30 log units) below; low and high end bracket the measured number.
By their numbers in this assay, from the lowest: compound 3; then compounds 4 and 1 (each within the scatter of the next); then compound 2.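

In this assay, this position responds to more than chain length: with the oxygen link and the number of chain carbons kept, deca-1,4-dien-1-yl in place of decyl gives a 3.5-fold higher number from compound 3 to compound 4 (0.54 log units; beyond the scatter) and so weakens binding beyond the usual scatter. Among these compounds, this pair is the first direct comparison, and it shows that adding 2 double bonds to the chain is enough to produce a real loss. No measurement shown here explains this loss.

Going by these compounds, it remains open whether a chain with only one of these double bonds would give part of the same step, or whether their placement along the chain matters. Also open, on these data alone, is how a dodecyl chain, or a decyl chain ending in a phenyl ring or an amine, would compare with decyl on the same oxygen.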